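The source may hold more compounds than are shown below. What is called first, only, known or untested is meant among the compounds shown, and "the series" means these compounds.

Measured compounds:
compound 1 `Nc1ccc(Nc2nc3ccccc3nc2S(=O)(=O)c2ccccc2)cc1`, 8720 nM in a functional assay on HL-60 cells (Homo sapiens) for cytotoxicity, read by MTT assay, with a stated time of 72 h; a lower number here means a stronger inhibitor, a higher number a weaker inhibitor
compound 2 `Nc1cccc(Nc2nc3ccccc3nc2S(=O)(=O)c2ccccc2)c1`, 1750 nM
compound 3 `COc1ccc(S(=O)(=O)c2nc3ccccc3nc2Nc2ccc(N)cc2)cc1`, 710 nM

Compound 3 has the lowest number of the three. The change from compound 1 to compound 2 is 3-aminophenyl in place of 4-aminophenyl on a nitrogen on an aromatic ring, and it gave a 5.0-fold lower number from compound 1 to compound 2 (0.70 log units; beyond the scatter). The cores of compound 1 and compound 3 differ by methoxy in place of hydrogen on an aromatic carbon, which gave a 12-fold lower number from compound 1 to compound 3 (1.09 log units; beyond the scatter). Compound 4 `COc1ccc(S(=O)(=O)c2nc3ccccc3nc2Nc2cccc(N)c2)cc1` is not yet measured. It differs from compound 3 by 3-aminophenyl in place of 4-aminophenyl on a nitrogen on an aromatic ring, the same change as from compound 1 to compound 2, made on the core of compound 3. In this assay compound 4 is therefore expected to show a 3.9-fold lower number from compound 3 to compound 4 (0.60 log units; beyond the scatter), resting on the step seen for the same change in compound 1 and compound 2, a 5.0-fold lower number from compound 1 to compound 2 (0.70 log units; beyond the scatter). The estimated value of compound 4 is 180 nM, with a range from 70 nM to 550 nM.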

Compound 4, half-maximal inhibitory concentration: 1490 nM
For compound 4 the middle estimate is 8.3-fold (0.92 log units) below the measured one; measured number outside the range, above it.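

In this assay, 3-aminophenyl in place of 4-aminophenyl did not carry over to the methoxy core, where it gave a 2.1-fold higher number from compound 3 to compound 4 (0.32 log units; beyond the scatter), so the direction of the step depended on the core: the same change on two cores in this assay, a 5.0-fold lower number (0.70 log units; beyond the scatter) from compound 1 to compound 2 and a 2.1-fold higher number (0.32 log units; beyond the scatter) from compound 3 to compound 4, 10-fold (1.02 log units) apart, beyond the scatter of two such steps Methoxy in place of hydrogen did not carry over either, giving only a 1.2-fold lower number from compound 2 to compound 4 (0.07 log units; within the scatter) on the 3-aminophenyl core, so the two changes did not add up: the same change on two cores in this assay, a 12-fold lower number (1.09 log units; beyond the scatter) from compound 1 to compound 3 and a 1.2-fold lower number (0.07 log units; within the scatter) from compound 2 to compound 4, 10-fold (1.02 log units) apart, beyond the scatter of two such steps These four compounds show that neither step can be transferred unchanged between these cores, but they do not show why, or whether this holds in any other assay.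

Going by these compounds, it stays open whether the same dependence on the core appears with a fluoro or methyl group in place of methoxy, or with a hydroxyl or acetamide group in place of the amino group.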